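Cytotoxicity notes on a quinolinone series in bladder carcinoma cells

The compounds below may be only part of what the source reports. "The series", "measured", "known", "first", "only" and "open" are said of these compounds alone.

Measured compounds:
compound 1, `COc1cccc2cc(-c3ccccc3)c(O)nc12`, 10000 nM
compound 2, `COc1ccc(-c2cc3c(OC)cc(OC)cc3n(C)c2=O)cc1`, 10000 nM

In a functional assay on T-24 cells (Homo sapiens) for cytotoxicity, read by colorimetric assay and MTT assay (on this read-out higher numbers stand for weaker inhibition and lower numbers for stronger inhibition), compound 1 gives 10000 nM. In this assay compound 2 gives 10000 nM, level with compound 1 at the digits shown, the two values lying within the scatter of each other.

Compound 3, `COc1ccc(-c2cc3c(OC)cc(OC)cc3n(CC(=O)O)c2=O)cc1`, is not yet measured in this assay. It differs from compound 2 by one change: carboxy in place of hydrogen on a saturated chain carbon bound to an aromatic nitrogen.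

With both measured compounds sitting at the same value, no step beyond the scatter is expected for this change; the estimate for the move from compound 2 to compound 3 is no change at the digits printed from compound 2 to compound 3 (within the scatter). Compound 3 is therefore expected to give about 10000 nM, in the range 5000 nM to 20000 nM.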

Compound 3, half-maximal inhibitory concentration: 10000 nM
Compound 3: middle estimate and measured number agree at the digits printed, within the range that was stated.
By their numbers in this assay, from the lowest: compounds 1, 2 and 3 (each within the scatter of the next).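

In this assay the change of methyl to carboxymethyl, on a saturated chain carbon bound to an aromatic nitrogen, reads no change at the digits printed from compound 2 to compound 3 (within the scatter) and so leaves the read-out unmoved at this position. Compounds 1 and 2 differ in more than one place and gave no single-change reading here. No supporting measurement bears on this result.

As far as these compounds go, whether an amine, an amide or a longer chain on this carbon would shift the value remains open. From the compounds shown here alone, the shared core's other positions also remain open, with only this one read by a single change.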